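The source may report more compounds than this note shows. Statements on the series, on what has been measured and on what is new or still open speak of the compounds shown alone.

Working notes on the series. The compounds share one core, shown in compound 1 `CNC(=O)c1cc(Oc2ccc(C(=O)/C=C/c3ccc(F)cc3Cl)cc2)ccn1`, and differ only in the aryl group on the enone chain. In a functional assay on A549 cells (Homo sapiens) for cytotoxicity, read by MTT assay, with a stated time of 72 h (a higher number here means a weaker inhibitor, a lower number a stronger inhibitor), compound 1 gives 21100 nM, the highest of the two numbers in hand. Compound 3 `CNC(=O)c1cc(Oc2ccc(C(=O)/C=C/c3ccc(Cl)cc3Cl)cc2)ccn1`, the nearest entry, gives 9460 nM in this assay; the step of a 2.2-fold lower number from compound 1 to compound 3 (0.35 log units; beyond the scatter) is modest but beyond the scatter. Compound 2 `CNC(=O)c1cc(Oc2ccc(/C=C/C(=O)c3ccc(C)cc3)cc2)ccn1`, which reverses the enone, stands at "not determined" (no result reported) in this assay and contributes no number.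

Compound 4 `CNC(=O)c1cc(Oc2ccc(C(=O)/C=C/c3ccc(Br)cc3)cc2)ccn1` is the next entry. Relative to compound 1 the change is 4-bromophenyl in place of 2-chloro-4-fluorophenyl on a double-bonded chain carbon bound to a double-bonded chain carbon. Within the data shown here, the only measured step that bears on this is the one from compound 1 to compound 3, which exchanged a single halogen and moved the number downward modestly. Among the measured compounds shown here, the change to compound 4 is larger: the chlorine of the 2-chloro-4-fluorophenyl group is removed entirely and a bromine enters in a 4-bromophenyl group, and no measured pair isolates either part of that. Given the small size of the one relevant step, a modest step is expected in this assay, most likely toward a lower number, but the direction is not secured.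

Compound 4 is therefore expected to give 14000 nM in this assay, in the range 5000 nM to 40000 nM, corresponding to the expected step of a 1.5-fold lower number from compound 1 to compound 4 (0.18 log units; within the scatter).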

Compound 4, half-maximal inhibitory concentration: > 50000 nM
Compound 4 gave a limit, no number (the forecaster's own chance of this, stated with the estimate: 10%); middle value at least 3.5-fold (0.55 log units) away from the limit.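

Compound 4 reads in this assay only as a limit and not as a number: the limit of > 50000 nM in this assay, at which 1 of the 4 values shown sits. On a double-bonded chain carbon bound to a double-bonded chain carbon, 4-bromophenyl in place of 2-chloro-4-fluorophenyl gives an at least 2.3-fold higher number from compound 1 to compound 4 (0.37 log units; beyond the scatter), and 4-bromophenyl in place of 2,4-dichlorophenyl gives an at least 5.2-fold higher number from compound 3 to compound 4 (0.72 log units; beyond the scatter); both steps are read against the limit, so their true size is not fixed. The earlier halogen exchange, a 2.2-fold lower number from compound 1 to compound 3 (0.35 log units; beyond the scatter), showed only a modest downward move between two aryl groups that each carry two halogens, whereas this result shows that a change of the aryl group at this place can also move the number upward, by more than that exchange did in the case of compound 3.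

The change to compound 4 removes the chlorine and the fluorine and brings in the bromine in a single step, so the compounds shown do not separate the contribution of each halogen. From the compounds shown here alone, what an aryl group carrying an amine or a carboxylic acid in place of the halogens would give in this assay also stays open.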